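One more methoxy on compound 2

A few compounds are considered here, and "the series" means these few. Any claim that something is new, unique, unknown or untested is made for them only; others in the source may bear on it.

In a functional assay on M14 cells (Homo sapiens) for inhibition, read by sulforhodamine B assay, with a stated time of 48 h (on this read-out higher numbers stand for weaker inhibition of growth and lower numbers for stronger inhibition of growth), compound 2 (`COc1cccc(C(=O)NNC(=O)c2ccc3[nH]c(-c4ccc([N+](=O)[O-])o4)nc3c2)c1`) gives 7.81 ug/mL as its result. Compound 1 (`O=C(NNC(=O)c1ccc2[nH]c(-c3ccc([N+](=O)[O-])o3)nc2c1)c1ccccc1`) gives 15.6 ug/mL on the same read-out, and these two values lie within the scatter of each other. Among the compounds with values here, they are the only two true numbers so far. Compound 3 (`O=C(NNC(=O)c1ccc2[nH]c(-c3ccc([N+](=O)[O-])o3)nc2c1)c1cccc(Oc2ccccc2)c1`) gives > 7.8 ug/mL as its result, and that is a limit of the assay, not a number.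

Compound 4 (`COc1ccc(C(=O)NNC(=O)c2ccc3[nH]c(-c4ccc([N+](=O)[O-])o4)nc3c2)cc1OC`) turns the 3-methoxyphenyl of compound 2 into a 3,4-dimethoxyphenyl (methoxy in place of hydrogen on an aromatic carbon). Within the data shown here, the closest precedent is the same kind of change, methoxy in place of hydrogen on an aromatic carbon, which gave a 2.0-fold lower number from compound 1 to compound 2 (0.30 log units; within the scatter) and so no move beyond the scatter. The phenoxy compound adds no size, as a step that the limit leaves unreadable from compound 1 to compound 3 and a step that the limit leaves unreadable from compound 2 to compound 3 show here. No shift beyond the scatter is therefore expected in this assay and the expected change is a 1.0-fold higher number from compound 2 to compound 4 (0.01 log units; within the scatter) at most. For compound 4 the estimated value is 8 ug/mL with 3.5 ug/mL to 16 ug/mL as its expected range.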

Compound 4, concentration for 50% growth inhibition: 15.6 ug/mL
Compound 4: middle estimate off by 2.0-fold (0.29 log units), on the low side; measured number inside the range.
By their numbers in this assay, from the lowest: compounds 2, 1 and 4 (each within the scatter of the next).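

In this assay, a methoxy placed ortho to a methoxy group and para to a large group gives a 2.0-fold higher number from compound 2 to compound 4 (0.30 log units; within the scatter), so this ring position accepts the group with no shift that can be told from the scatter. Replacing phenyl with 3,4-dimethoxyphenyl gives no change at the digits printed from compound 1 to compound 4 (within the scatter), so two methoxy groups on the ring also produce no readable shift. The earlier compounds had shown this only for a single methoxy, so compounds 1, 2 and 4 now form a set in which neither step of added methoxy stands out.

Still open, from the compounds shown here alone, is whether an amine, a carboxylic acid or a longer chain at this position would move the number beyond the scatter. The result for compound 3 is a limit, not a number: the limit of > 7.8 ug/mL in this assay, at which 1 of the 4 values shown sits.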